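Swapping a Chlorophenyl for a Chloropyridyl on a Shared Core

The source may hold more compounds than are shown below. What is called first, only, known or untested is meant among the compounds shown, and "the series" means these compounds.

Compound 1 `CCOc1ccc(-c2nnc(SCCn3c([N+](=O)[O-])cnc3C)o2)cc1` gives 14100 nM in a functional assay on SGC-7901 cells (Homo sapiens) for cytotoxicity, read by MTT assay, with a stated time of 48 h; on this read-out higher numbers stand for weaker inhibition and lower numbers for stronger inhibition.
Compound 2 `Cc1ncc([N+](=O)[O-])n1CCSc1nnc(-c2ccccc2[N+](=O)[O-])o1` gives 30000 nM.
Compound 3 `Cc1ncc([N+](=O)[O-])n1CCSc1nnc(-c2ccccc2Cl)o1` gives 32600 nM.

Compound 3 has the highest number of the three measured, within the scatter of compound 2 but beyond it relative to compound 1. Compound 4 `Cc1ncc([N+](=O)[O-])n1CCSc1nnc(-c2ccnc(Cl)c2)o1` differs from compound 3 in one place: 2-chloropyridin-4-yl in place of 2-chlorophenyl on an aromatic carbon. Within the data shown here, no measured step exchanges a carbon-only ring for a ring with one hetero atom here; the only measured step, a 1.1-fold higher number from compound 2 to compound 3 (0.04 log units; within the scatter), swaps one substituent on the same ring and stays within the scatter. With nothing bearing directly on this change, no shift beyond the scatter is expected, so the step is expected to be a 1.1-fold lower number from compound 3 to compound 4 (0.04 log units; within the scatter). Compound 4 is therefore expected near 30000 nM, with a range of 12000 nM to 70000 nM.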

Compound 4, half-maximal inhibitory concentration: 32300 nM
For compound 4 the middle estimate is 1.1-fold (0.03 log units) below the measured one, and the stated range covers the measured number.
By their numbers in this assay, from the lowest: compound 1; then compounds 2, 4 and 3 (each within the scatter of the next).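

In this assay putting 2-chloropyridin-4-yl in place of 2-chlorophenyl gives a 1.0-fold lower number from compound 3 to compound 4 (0.00 log units; within the scatter) and so adds a ring nitrogen, counted as a hydrogen-bond acceptor, with no shift beyond the scatter. Unlike the swap of nitro for chloro, this change alters the ring itself rather than a substituent on it. Nothing available explains this flat result. As far as these compounds go, whether an amine or a carboxylic acid on this ring would move the number remains open. So does the effect of a longer chain at this position.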